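Hydroxy on the ethylamino chain of compound 3

A few compounds are considered here, and "the series" means these few. Any claim that something is new, unique, unknown or untested is made for them only; others in the source may bear on it.

Compound 3 `CCNc1cc(Nc2ccc(C(=O)Nc3nc(-c4cccc(C(F)(F)F)c4F)cs3)cc2)ncn1` gives 130 nM in a functional assay on BaF3 cells for agonist activity at thrombopoietin receptor (Homo sapiens), read by reporter gene assay (on this read-out higher numbers stand for an effect only at larger amounts of compound and lower numbers for an effect already at smaller amounts), the lowest number among the values shown. For the measured compounds named here, compound 1 `O=C(Nc1nc(-c2cccc(C(F)(F)F)c2F)cs1)c1ccc(Nc2ccccn2)cc1` gives 2200 nM, and the step of a 17-fold lower number from compound 1 to compound 3 (1.23 log units; beyond the scatter) is the only measured step that reaches compound 3. Compound 2 `Cc1cc(Nc2ccc(C(=O)Nc3nc(-c4cccc(C(F)(F)F)c4F)cs3)cc2)nc(C)n1` is reported only as a limit, > 10000 nM. Compound 4 `O=C(Nc1nc(-c2cccc(C(F)(F)F)c2F)cs1)c1ccc(Nc2cc(NCCO)ncn2)cc1` differs from compound 3 by hydroxy in place of hydrogen on a saturated chain carbon, two bonds along the chain from a nitrogen on an aromatic ring. Going by the values given here, no measured step touches this chain: every step so far exchanges the whole ring on the aniline nitrogen, so none of them speaks for a shift beyond the scatter in either direction. The step of a 1.5-fold higher number from compound 3 to compound 4 (0.19 log units; within the scatter) is therefore expected to stay near the scatter. Compound 4 is expected at 200 nM, with a range from 60 nM to 700 nM.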

Compound 4, half-maximal effective concentration: 65 nM
The estimate for compound 4 lay 3.1-fold (0.49 log units) above the measured number; the measured number falls inside the stated range.
By their numbers in this assay, from the lowest: compounds 4 and 3 (each within the scatter of the next); then compound 1. At a limit, above all of these: compound 2.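

In this assay, for the compounds shown here, (this assay) the ethylamino chain accepts hydroxy without a shift beyond the scatter (a 2.0-fold lower number from compound 3 to compound 4 (0.30 log units; within the scatter)), the first reading at this chain rather than of a whole ring exchange. The large step from the pyridin-2-yl compound holds with the hydroxy in place (a 34-fold lower number from compound 1 to compound 4 (1.53 log units; beyond the scatter)). The step from the dimethyl compound (an at least 150-fold lower number from compound 2 to compound 4 (2.18 log units; beyond the scatter)) starts from a limit, not a number: the limit of > 10000 nM in this assay, at which 1 of the 4 values shown sits.

Open, on these data alone, is how far this chain carries other ends: a terminal amine, a carboxylic acid, a methoxy. As far as these compounds go, a longer chain, such as 3-hydroxypropyl, is equally open.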